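The source may hold more compounds than are shown below. What is called first, only, known or untested is meant among the compounds shown, and "the series" means these compounds.

Compound 1 `O=C(O)CCNC(=O)c1ccc(C(Oc2ccc(-n3cc(C(F)(F)F)cn3)cc2)C2CC2)cc1`: < 25 mL/min/kg
Compound 2 `O=C(O)CCNC(=O)c1ccc(C(Oc2ccc(-n3cc(C(F)(F)F)cn3)cc2)C2CCC2)cc1`: < 25 mL/min/kg
Compound 3 `CCC(Oc1ccc(-n2cc(C(F)(F)F)cn2)cc1)c1ccc(C(=O)NCCC(=O)O)cc1`: < 25 mL/min/kg

All three compounds were read in an ADME assay on microsomes from liver (Rattus norvegicus) for metabolic stability (on this read-out higher numbers stand for fast clearance and lower numbers for slow clearance), and each entry is a limit of the assay, not a number. Compound 3 stands at < 25 mL/min/kg, which is such a limit. It shares that place with the other two compounds, as the limit of < 25 mL/min/kg in this assay, at which 3 of the 3 values shown sit, shows, so the numbers give no order among them.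

Compound 4 `O=C(O)CCNC(=O)c1ccc(C(Oc2ccc(-n3cc(C(F)(F)F)cn3)cc2)C2CCCC2)cc1` has not yet been measured. It differs from compound 3 by cyclopentyl in place of ethyl on a saturated chain carbon bound to an aromatic carbon and an oxygen on an aromatic ring.

The measured steps that bear on this change are those made at the same place. They are a step that the two limits leave unreadable from compound 1 to compound 3, a step that the two limits leave unreadable from compound 2 to compound 3 and a step that the two limits leave unreadable from compound 1 to compound 2. None of them has a readable size, so they support no step beyond the scatter in this assay and no direction. The expected step is therefore none beyond the scatter, and the estimate is a step that the limit leaves unreadable from compound 3 to compound 4. Compound 4 is expected to be reported most probably as a limit too. For compound 4 the estimated clearance is 15 mL/min/kg, with an expected range from 6 mL/min/kg to 30 mL/min/kg.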

Compound 4, clearance: 31 mL/min/kg
For compound 4 the middle estimate is 2.1-fold (0.32 log units) below the measured one; measured number outside the range, above it.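

Among these compounds, compound 4, with cyclopentyl on the saturated chain carbon bound to an aromatic carbon and an oxygen on an aromatic ring, is the only one of the four compounds with a number rather than a limit in this assay, so this position can now give a value that the assay reports in full, while the other three compounds remain at a limit: the limit of < 25 mL/min/kg in this assay, at which 3 of the 4 values shown sit. Cyclopentyl in place of ethyl gives an at least 1.2-fold higher number from compound 3 to compound 4 (0.09 log units; that floor lies within the scatter), in place of cyclobutyl it gives an at least 1.2-fold higher number from compound 2 to compound 4 (0.09 log units; that floor lies within the scatter), and in place of cyclopropyl it gives an at least 1.2-fold higher number from compound 1 to compound 4 (0.09 log units; that floor lies within the scatter). Each of these is only a floor and lies within the scatter, so the new value marks a possible rise in clearance with the cyclopentyl group but does not establish one.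

The steps among the three compounds held at the limit cannot be read, so neither the true size of the steps to compound 4 nor any order among ethyl, cyclopropyl and cyclobutyl can be told. Also open, on these data alone, is whether a cyclohexyl ring or a longer chain such as butyl at this carbon would give a number clearly beyond the scatter.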